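Working notes on cytotoxicity for compounds 1 to 3

This account rests on a few compounds, and the source may have more. Where it says the series, first, only, none or still open, it means among the compounds named here.

Measured so far. Compound 1 `CC(C)N(Cc1cccc(OCCCCCC(=O)O)c1)C(=O)c1ccc(-c2cccc(N(C)C)c2)cc1` gives > 26000 nM in an ADME assay on BJ cells (Homo sapiens) for cytotoxicity, read by CellTiter-Glo and resazurin assay, with a stated time of 72 h; a higher number here means that more compound is needed for the effect, a lower number that less compound is needed; that value is a limit of the assay, not a number. Compound 2 `CC(C)N(Cc1cccc(OCCCCCC(=O)O)c1)C(=O)c1ccccc1` gives > 26000 nM in this assay, again a limit rather than a number.

Because both values are limits, the step that the two limits leave unreadable from compound 1 to compound 2 cannot be read in either direction. Within the data shown here, compound 2 therefore stands at the limit of > 26000 nM in this assay, at which 2 of the 2 values shown sit, and the one further value shown is itself a limit. Among the measured compounds shown here, no compound in the set has a measured number in this assay.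

The unmeasured compound 3 `CC(C)N(Cc1cccc(OCCCCCC(=O)O)c1)C(=O)c1ccc(-c2cccc3ccccc23)cc1` differs from compound 2 by naphthalen-1-yl in place of hydrogen on an aromatic carbon. For the measured compounds named here, the only measured step, a step that the two limits leave unreadable from compound 1 to compound 2, concerns a change at the same aromatic carbon, but its size is not readable, so it gives no direction and no magnitude to carry over. Nothing in the measured values points to a readable step in this assay.

Compound 3 is therefore expected to sit at 40000 nM, with a range of 15000 nM to 100000 nM, most likely again reported only as a limit. The expected step that the limit leaves unreadable from compound 2 to compound 3 is estimated to be none beyond the scatter.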

Compound 3, half-maximal effective concentration: < 1.3 nM
Compound 3: only a limit was reported; the forecaster's own chance of this, stated with the estimate: 85%; at least 30000-fold (4.48 log units) between middle value and limit.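

Compound 3 is the only compound here at the low end of this assay, and its value is a limit and not a number: the limit of < 1.3 nM in this assay, at which 1 of the 3 values shown sits.

Naphthalen-1-yl in place of hydrogen on this aromatic carbon gives an at least 20000-fold lower number from compound 2 to compound 3 (4.30 log units; beyond the scatter), so a change at this position can produce a readable step, which the earlier pair, with its two limits, could not show. Naphthalen-1-yl in place of 3-(dimethylamino)phenyl at the same carbon gives an at least 20000-fold lower number from compound 1 to compound 3 (4.30 log units; beyond the scatter), so in this pair the identity of the group matters and not merely the presence of an aromatic ring at that carbon.

Open, on these data alone, is whether a plain phenyl or a naphthalen-2-yl at the same carbon would read as a number or as a limit, and so which part of naphthalen-1-yl goes with the step. Also open, as far as these compounds go, are the true value of compound 3 beyond its limit and whether the step persists with a methyl ester in place of the carboxylic acid.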